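A few compounds are considered here, and "the series" means these few. Any claim that something is new, unique, unknown or untested is made for them only; others in the source may bear on it.

Compound 1 `O=C(O)Cc1sc(C(c2ccc(F)cc2)c2ccc(F)cc2)nc1-c1ccco1`: 80%
Compound 2 `O=C(O)Cc1sc(C(c2ccccc2)c2ccccc2)nc1-c1ccc(C(F)(F)F)cc1`: 80%

In an in vitro functional assay on HEK285-7 cells for antagonist activity at prostaglandin D2 receptor 2 (Homo sapiens), read by BRET and beta-arrestin recruitment (on this read-out higher numbers stand for larger maximal responses and lower numbers for smaller maximal responses), compound 1 gives 80%, level with compound 2, which gives 80% in this assay; the two values lie within the scatter of each other. Compound 3 `O=C(O)Cc1sc(C(c2ccc(F)cc2)c2ccc(F)cc2)nc1-c1cc(F)nc(F)c1` differs from compound 1 by one exchange, (2,6-difluoropyridin-4-yl in place of furan-2-yl on an aromatic carbon). Among the compounds with values here, no step between measured compounds covers this exchange, so any expectation rests on compound 1 alone. For compound 3 the step of a number 2 percentage points lower from compound 1 to compound 3 (within the scatter) is expected to stay within the scatter, with no clear direction. Compound 3 is estimated at 78%, in a range from 60% to 95%.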

Compound 3, largest response reached (reported as efficacy), in percent of the reference or control that the assay uses: 80%
Beside the measured number, compound 3's estimate is 2 percentage points below it; low and high end bracket the measured number.
By their numbers in this assay, from the lowest: compounds 1, 2 and 3 (each within the scatter of the next).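

In this assay, placing 2,6-difluoropyridin-4-yl instead of furan-2-yl on the aromatic carbon next to the ring nitrogen gives no change at the digits printed from compound 1 to compound 3 (within the scatter). Within the data shown here, this is the first single-place comparison, and it shows that a six-membered aromatic ring can replace the five-membered one at this position without a change beyond the scatter. Nothing measured here accounts for this result. From the compounds shown here alone, whether an amine or a morpholine ring at this carbon would read the same remains open, as does the effect of a longer chain in place of the carboxymethyl group.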